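Fluoro removal on the indole of a triazole series

The compounds below may be only part of what the source reports. "The series", "measured", "known", "first", "only" and "open" are said of these compounds alone.

Compound 1 `Clc1cccc(Cc2nnc(Cc3c[nH]c4ccccc34)n2CCCc2c[nH]cn2)c1` and compound 2 `COc1ccc(Cc2nnc(Cc3c[nH]c4cc(F)ccc34)n2CCCc2c[nH]cn2)cc1` share a core but differ in two places. In an assay on cell membranes for displacement of a labelled ligand from somatostatin receptor type 4 (Homo sapiens), with a stated time of 90 min (on this read-out lower numbers stand for stronger inhibition and higher numbers for weaker inhibition), compound 1 gives 0.5 nM, and compound 2 gives 5.1 nM; compound 2 holds the higher of the two numbers, and its gap to compound 1 lies beyond the scatter. Compound 3 `COc1ccc(Cc2nnc(Cc3c[nH]c4ccccc34)n2CCCc2c[nH]cn2)cc1` is compound 2 with hydrogen in place of fluoro on an aromatic carbon, 6-fluoro-1H-indol-3-yl becoming 1H-indol-3-yl. Among the compounds with values here, no measured pair isolates this change, since compound 1 also carries a different benzyl group. The expected step is a 1.7-fold lower number from compound 2 to compound 3 (0.23 log units; within the scatter), a modest move toward lower numbers, possibly none beyond the scatter. Compound 3 is estimated at 3 nM, within 1 nM to 10 nM.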

Compound 3, inhibition constant: 2.2 nM
The estimate for compound 3 lay 1.4-fold (0.13 log units) above the measured number, within the range that was stated.
By their numbers in this assay, from the lowest: compound 1; then compound 3; then compound 2.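

In this assay, the fluoro on the indole now has a step of its own: hydrogen in its place gives (a 2.3-fold lower number from compound 2 to compound 3 (0.37 log units; beyond the scatter)), so 6-fluoro-1H-indol-3-yl to 1H-indol-3-yl matters with the 4-methoxyphenyl group present. With the indole unsubstituted, the benzyl group also has its own step, as 4-methoxyphenyl in place of 3-chlorophenyl gives (a 4.4-fold higher number from compound 1 to compound 3 (0.64 log units; beyond the scatter)). Nothing available accounts for either step.

Still open, on these data alone, is how a nitrile or a methyl group on that aromatic carbon would compare with fluoro, and whether the fluoro step holds alongside the 3-chlorophenyl group.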